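Adding a Second Fluoro Where Two Compounds Show Nothing

A few compounds are considered here, and "the series" means these few. Any claim that something is new, unique, unknown or untested is made for them only; others in the source may bear on it.

Compound 1 `CC(C)N1CCN(Cc2csc(N)c2C(=O)c2ccc(Cl)cc2)CC1`: in an assay on CHO cells for displacement of a labelled ligand from adenosine receptor A1 (Homo sapiens), read by scintillation counting, with a stated time of 120 min, tested at 10 uM (a higher number here means more inhibition at the concentration tested (going by the name of the read-out), a lower number less inhibition), compound 1 gives 0%
Compound 2 `Nc1scc(CN2CCN(c3cccc(F)c3)CC2)c1C(=O)c1ccc(Cl)cc1`: in this assay compound 2 gives 1%

Among these two numbers compound 2 stands highest, yet its only neighbour is compound 1 and the step of a number 1 percentage points higher from compound 1 to compound 2 (within the scatter) lies within the scatter, so the two compounds cannot be told apart; both show essentially no inhibition at the concentration tested.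

Compound 3 `Nc1scc(CN2CCN(c3cc(F)cc(F)c3)CC2)c1C(=O)c1ccc(Cl)cc1` has not yet been measured in this assay. It differs from compound 2 as fluoro in place of hydrogen on an aromatic carbon; cut one bond further out, the change reads 3-fluorophenyl to 3,5-difluorophenyl. Going by the values given here, only one measured step bears on it, a number 1 percentage points higher from compound 1 to compound 2 (within the scatter), which swapped isopropyl for 3-fluorophenyl on the amine nitrogen in the ring and stayed within the scatter. Nothing in the data points to a step beyond the scatter for a further fluoro. Compound 3 is therefore expected at 2%, with a range from -8% to 12%. For compound 3 this means an expected step of a number 1 percentage points higher from compound 2 to compound 3 (within the scatter).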

Compound 3, a percentage reported as inhibition, at one concentration (the size of the read-out at that concentration, not a potency): 0%
The estimate for compound 3 lay 2 percentage points above the measured number, and the stated range covers the measured number.
By their numbers in this assay, from the lowest: compounds 1, 3 and 2 (each within the scatter of the next).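

Putting fluoro in place of hydrogen on the aromatic carbon, meta to a fluoro group, gives a number 1 percentage points lower from compound 2 to compound 3 (within the scatter) in this assay, so a second fluoro on this ring does not separate the 3,5-difluorophenyl compound from its 3-fluorophenyl neighbour. Set against the isopropyl group on the amine nitrogen in the ring, the 3,5-difluorophenyl group gives no change at the digits printed from compound 1 to compound 3 (within the scatter), so neither aryl group tried here stands apart from the alkyl group, and all three compounds remain indistinguishable at the concentration tested. No measurement is available that would explain this flat result.

On these data alone, what stays open is whether a larger or differently charged group at this position, such as a methoxy group, an amine or a carboxylic acid, would produce any measurable inhibition. Changes elsewhere on the shared core also remain untested by these compounds, and a single-concentration read-out says nothing about potency.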